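Swapping the sulfonyl aryl group: from dichloro to dimethyl

The compounds below may be only part of what the source reports. "The series", "measured", "known", "first", "only" and "open" are said of these compounds alone.

Measured so far:
- compound 1, `O=S(=O)(c1cc(Cl)cc(Cl)c1)c1cnc2cc(F)ccc2c1-c1ccc(Cl)cc1`: 0.13 mL/min
- compound 2, `O=S(=O)(c1cc(Cl)cc(Cl)c1)c1cnc2cc(F)ccc2c1-c1cccc(F)c1`: 0.41 mL/min
- compound 3, `O=S(=O)(c1cc(Cl)cc(Cl)c1)c1cnc2cc(F)ccc2c1-c1cccc(Cl)c1`: 0.93 mL/min

All three were run in an ADME assay on microsomes from liver (Homo sapiens) for metabolic stability, tested at 2.5 uM; a lower number here means slower removal, a higher number faster removal of the compound. Compound 1 stands lowest of the three: compound 2 sits a 3.2-fold higher number from compound 1 to compound 2 (0.50 log units; beyond the scatter), and compound 3 sits a 7.2-fold higher number from compound 1 to compound 3 (0.85 log units; beyond the scatter); between those two, a 2.3-fold higher number from compound 2 to compound 3 (0.36 log units; beyond the scatter). Each of these steps changes the group on an aromatic carbon of the shared core.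

Compound 4, `Cc1ccc(S(=O)(=O)c2cnc3cc(F)ccc3c2-c2ccc(Cl)cc2)cc1C`, is built differently from compound 1: 3,4-dimethylphenyl in place of 3,5-dichlorophenyl on a sulfonyl sulfur. Within the data shown here, this change sits on a sulfonyl sulfur, a place that none of the measured steps touched, so none of them bears on it directly. All they show is that a single change on one aryl group of this core moved the number by modest, measurable amounts, always upward from compound 1. Among the measured compounds shown here, with no step at this position to lean on, a modest rise is expected for compound 4, about a 3.5-fold higher number from compound 1 to compound 4 (0.54 log units; beyond the scatter), with a wide range. The estimate for compound 4 in this assay is 0.45 mL/min, between 0.13 mL/min and 1.5 mL/min.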

Compound 4, intrinsic clearance in a liver preparation (reported as CLH), per the amount of preparation that the assay uses: 7.88 mL/min
Beside the measured number, compound 4's estimate is 18-fold (1.24 log units) below it; measured number above the stated range.
By their numbers in this assay, from the lowest: compound 1; then compound 2; then compound 3; then compound 4.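

In this assay, among these compounds, replacing 3,5-dichlorophenyl with 3,4-dimethylphenyl on the sulfonyl sulfur gives a 61-fold higher number from compound 1 to compound 4 (1.78 log units; beyond the scatter), a much bigger jump than the largest change among the earlier compounds, a 7.2-fold higher number from compound 1 to compound 3 (0.85 log units; beyond the scatter), so this position matters strongly for the read-out. The size of the step does not follow from the simple counts, as both groups have 8 heavy atoms and one six-membered aromatic ring of carbon only, with no hydrogen-bond donors or acceptors and no net charge. Nothing available explains why the number rose so far.

This single step swaps both the substituent type and their arrangement on the ring, so the two effects remain tangled. Also open, from the compounds shown here alone, are whether the rise would recur with the 3-fluorophenyl of compound 2, and how a sulfonyl aryl group carrying a methoxy group, an amine or a carboxylic acid would behave.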